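The compounds below may be only part of what the source reports. "The series", "measured", "known", "first", "only" and "open" are said of these compounds alone.

Compound 1 `O[C@@H](c1ccccc1)[C@H]1CO[C@H](c2ccccc2)[C@@H](C/C=C/c2ccncc2)C1`: in a functional assay on HeLa cells (Homo sapiens) for cytotoxicity, read by WST assay, with a stated time of 48 h (on this read-out higher numbers stand for weaker inhibition and lower numbers for stronger inhibition), compound 1 gives > 100000 nM, a limit of the assay rather than a number.
Compound 2 `O=[N+]([O-])c1ccccc1/C=C/C[C@H]1C[C@@H]([C@@H](O)c2ccccc2)CO[C@@H]1c1ccccc1`: compound 2 gives 11800 nM.
Compound 3 `CCCCCC/C=C/C[C@H]1C[C@@H]([C@@H](O)c2ccccc2)CO[C@@H]1c1ccccc1`: compound 3 gives 7400 nM.

Among the compounds with values here, compound 3 has the lowest number of the two numbers known, but compound 2 is within the scatter of it, so they cannot be ordered. Compound 4 `Oc1ccccc1/C=C/C[C@H]1C[C@@H]([C@@H](O)c2ccccc2)CO[C@@H]1c1ccccc1` is not yet measured; it differs from compound 3 in one place: 2-hydroxyphenyl in place of hexyl on a double-bonded chain carbon bound to a double-bonded chain carbon. Within the data shown here, two measured steps bear on a swap at this position. The step of a 1.6-fold lower number from compound 2 to compound 3 (0.20 log units; within the scatter) shows one aromatic ring in place of hexyl costing nothing, whereas an at least 13-fold lower number from compound 1 to compound 3 (1.13 log units; beyond the scatter) shows another ring giving a far weaker compound 1 that only reached (the limit of > 100000 nM in this assay, at which 1 of the 3 values shown sits). For compound 4 a modest rise is expected, a 2.0-fold higher number from compound 3 to compound 4 (0.31 log units; beyond the scatter), with compound 4 estimated at 15000 nM, between 5000 nM and 60000 nM.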

Compound 4, half-maximal inhibitory concentration: 21800 nM
For compound 4 the middle estimate is 1.5-fold (0.16 log units) below the measured one; measured number inside the range.
By their numbers in this assay, from the lowest: compounds 3, 2 and 4 (each within the scatter of the next, the first and the last beyond it). At a limit, above all of these: compound 1.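

Compound 4 shows that an aromatic ring at this position can cost something against hexyl: the change gives a 2.9-fold higher number from compound 3 to compound 4 (0.47 log units; beyond the scatter) and this gap is beyond the scatter. Replacing nitro with hydroxy on the ring gives a 1.8-fold higher number from compound 2 to compound 4 (0.27 log units; within the scatter) and so leaves no readable difference between those two ring substituents. The 2-hydroxyphenyl compound also keeps its edge over the pyridin-4-yl compound, with an at least 4.5-fold lower number from compound 1 to compound 4 (0.66 log units; beyond the scatter) as the step, but compound 1 stands at a limit of the assay, not a number: the limit of > 100000 nM in this assay, at which 1 of the 4 values shown sits.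

From the compounds shown here alone, what an amine on this aromatic ring, or a chain longer than hexyl, would give remains open.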